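Free carboxylic acid in place of a methyl carbamate

The compounds below may be only part of what the source reports. "The series", "measured", "known", "first", "only" and "open" are said of these compounds alone.

Measured compounds and their values in a functional assay on HEL cells (Homo sapiens); on this read-out higher numbers stand for lower toxicity in this test and lower numbers for higher toxicity in this test:
- compound 1, `COC(=O)C(=O)CNC1=CS(=O)(=O)O[C@@]12[C@@H](CO[Si](C)(C)C(C)(C)C)O[C@@H](n1cc(C)c(=O)n(C)c1=O)[C@@H]2O[Si](C)(C)C(C)(C)C`: > 200000 nM
- compound 2, `Cc1cn([C@@H]2O[C@H](CO[Si](C)(C)C(C)(C)C)[C@@]3(OS(=O)(=O)C=C3NCCC(=O)O)[C@H]2O[Si](C)(C)C(C)(C)C)c(=O)n(C)c1=O`: 34000 nM
- compound 3, `COC(=O)NC1=CS(=O)(=O)O[C@@]12[C@@H](CO[Si](C)(C)C(C)(C)C)O[C@@H](n1cc(C)c(=O)n(C)c1=O)[C@@H]2O[Si](C)(C)C(C)(C)C`: > 200000 nM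

Compound 3 sits at a limit of this assay, not at a number, and compound 1 sits at the same limit. Compound 2 is the only one of the three with a measured number, and it is the lowest value shown. The step of an at least 5.8-fold higher number from compound 2 to compound 3 (0.76 log units; beyond the scatter) therefore came with methoxycarbonyl in place of 2-carboxyethyl on the amine nitrogen, while a step that the two limits leave unreadable from compound 1 to compound 3 cannot be sized, as the limit of > 200000 nM in this assay, at which 2 of the 3 values shown sit, shows.

Compound 4, `Cc1cn([C@@H]2O[C@H](CO[Si](C)(C)C(C)(C)C)[C@@]3(OS(=O)(=O)C=C3NCC(=O)O)[C@H]2O[Si](C)(C)C(C)(C)C)c(=O)n(C)c1=O`, differs from compound 3 by carboxymethyl in place of methoxycarbonyl on an amine nitrogen. This change runs opposite to the step from compound 2 to compound 3: a carboxylic acid on a short chain again replaces the methyl carbamate, with the chain one carbon shorter than in compound 2. The step of an at least 5.8-fold lower number from compound 1 to compound 2 (0.76 log units; beyond the scatter) also ended in the acid-bearing compound at a measured number. Compound 4 is therefore expected to leave the limit and return toward the value of compound 2, with an at least 4.0-fold lower number from compound 3 to compound 4 (0.60 log units; beyond the scatter) as the expected step. Compound 4 is estimated at 50000 nM, within 15000 nM to 200000 nM.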

Compound 4, half-maximal cytotoxic concentration: 136000 nM
The estimate for compound 4 lay 2.7-fold (0.43 log units) below the measured number, and the stated range covers the measured number.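

In this assay, among these compounds, the step of a 4.0-fold higher number from compound 2 to compound 4 (0.60 log units; beyond the scatter) shows for the first time that the length of the acid-bearing chain on this amine nitrogen counts, since going from 2-carboxyethyl to carboxymethyl moves the number beyond the scatter. Carboxymethyl in place of methoxycarbonyl, by contrast, gives only an at least 1.4-fold lower number from compound 3 to compound 4 (0.16 log units; that floor lies within the scatter), and hydroxy in place of methoxycarbonyl on the carbonyl carbon gives an at least 1.4-fold lower number from compound 1 to compound 4 (0.16 log units; that floor lies within the scatter), so neither step can be told apart from the usual scatter of repeated measurements. A free carboxylic acid on this nitrogen therefore does not by itself carry a compound clearly away from the limit, and the true size of both steps stays unknown: the limit of > 200000 nM in this assay, at which 2 of the 4 values shown sit.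

The compounds shown leave open how a longer chain ending in a carboxylic acid would read, and so whether the trend from carboxymethyl to 2-carboxyethyl continues. They also leave open whether a methyl ester on the 2-carboxyethyl chain would keep the number of compound 2 or return to the limit, which would separate the effect of the acid from that of the chain.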